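Hydrogen in place of methyl at compound 2

A few compounds are considered here, and "the series" means these few. Any claim that something is new, unique, unknown or untested is made for them only; others in the source may bear on it.

Measured in a functional assay on HeLa cells (Homo sapiens) for cytotoxicity, read by MTT assay, with a stated time of 72 h; on this read-out lower numbers stand for stronger inhibition and higher numbers for weaker inhibition:
- compound 1 `Cn1ccc2c(Oc3ccc(NC(=O)c4cc5cccnc5n(-c5ccc(Br)cc5)c4=O)cc3)ncnc21` gives 43800 nM
- compound 2 `Cn1ccc2c(Oc3ccc(NC(=O)c4cc5cccnc5n(-c5ccc(Br)cc5)c4=O)cc3F)ncnc21` gives 33800 nM

For the measured compounds named here, compound 2 cannot be told apart from compound 1, the only other measured compound, since a 1.3-fold lower number from compound 1 to compound 2 (0.11 log units; within the scatter) stays within the scatter. Compound 3 `O=C(Nc1ccc(Oc2ncnc3[nH]ccc23)c(F)c1)c1cc2cccnc2n(-c2ccc(Br)cc2)c1=O` comes from compound 2 through one change hydrogen in place of methyl on an aromatic nitrogen in which hydrogen takes the place of methyl on an aromatic nitrogen. Going by the values given here, no measured step covers this change. Among the compounds with values here, the one step available, a 1.3-fold lower number from compound 1 to compound 2 (0.11 log units; within the scatter) for fluoro in place of hydrogen on an aromatic carbon, is a different change and sets no size or direction for it. No shift beyond the scatter is therefore expected in this assay, though this rests on little evidence. The expected move is a 1.1-fold lower number from compound 2 to compound 3 (0.05 log units; within the scatter) and it stays within the scatter. For compound 3 the estimate is 30000 nM with an expected range from 10000 nM to 70000 nM on this basis.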

Compound 3, half-maximal inhibitory concentration: 19900 nM
The estimate for compound 3 lay 1.5-fold (0.18 log units) above the measured number; low and high end bracket the measured number.
By their numbers in this assay, from the lowest: compounds 3, 2 and 1 (each within the scatter of the next, the first and the last beyond it).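

In this assay the change on the aromatic nitrogen of the five-membered aromatic ring reads as a 1.7-fold lower number from compound 2 to compound 3 (0.23 log units; within the scatter) so hydrogen and methyl at this position cannot be told apart. For the compounds shown here, this is the first reading at this position, and it gives no sign that the methyl is needed for the number seen with compound 2. Nothing at hand bears on why the two compounds read alike.

Still open, going by these compounds, is whether an ethyl group, a longer chain or a chain ending in an amine or a carboxylic acid on this nitrogen would move the number beyond the scatter. Also open, on these data alone, is whether hydrogen in place of methyl reads the same way on the core of compound 1, which carries hydrogen instead of fluoro on the aromatic carbon.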